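The source may hold more compounds than are shown below. What is called first, only, known or untested is meant among the compounds shown, and "the series" means these compounds.

In a functional assay on SW 1116 cells (Homo sapiens) for cytotoxicity, read by MTT assay, with a stated time of 48 h (on this read-out lower numbers stand for stronger inhibition and higher numbers for weaker inhibition), compound 1 `O=C(CSc1nnc(-c2ccncc2)o1)N/N=C/c1ccc(Br)cc1` gives 21300 nM, compound 2 `O=C(CSc1nnc(-c2ccncc2)o1)N/N=C/c1ccccc1O` gives 7380 nM, and compound 3 `O=C(CSc1nnc(-c2ccncc2)o1)N/N=C/c1cc(Cl)ccc1O` gives 5240 nM. Compound 3 holds the lowest of the three numbers, yet its separation from compound 2 is only a 1.4-fold lower number from compound 2 to compound 3 (0.15 log units; within the scatter), whereas its separation from compound 1 is a 4.1-fold lower number from compound 1 to compound 3 (0.61 log units; beyond the scatter). Compound 4 `O=C(CSc1nnc(-c2ccncc2)o1)N/N=C/c1ccc(O)c(O)c1` has not yet been measured in this assay; it differs from compound 3 in a single place: 3,4-dihydroxyphenyl in place of 5-chloro-2-hydroxyphenyl on a carbon with a double bond to nitrogen. For the measured compounds named here, two measured steps bear on this change. Putting a 2-hydroxyphenyl in place of the 4-bromophenyl gave a 2.9-fold lower number from compound 1 to compound 2 (0.46 log units; beyond the scatter), a modest gain, and introducing chloro in place of hydrogen on an aromatic carbon gave a 1.4-fold lower number from compound 2 to compound 3 (0.15 log units; within the scatter), which does not rise above the scatter. Compound 4 retains a hydroxyl, gains a second one, and loses the chloro, so the expected outcome is a small change, if any, of a 1.0-fold lower number from compound 3 to compound 4 (0.02 log units; within the scatter). Compound 4 is accordingly estimated at 5000 nM, with a range from 2000 nM to 13000 nM.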

Compound 4, half-maximal inhibitory concentration: 1540 nM
The estimate for compound 4 lay 3.2-fold (0.51 log units) above the measured number; measured number below the stated range.
By their numbers in this assay, from the lowest: compound 4; then compounds 3 and 2 (each within the scatter of the next); then compound 1.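

In this assay, the group on the carbon with a double bond to nitrogen proves able to move the number even among hydroxyl-bearing rings: 3,4-dihydroxyphenyl gives a 3.4-fold lower number from compound 3 to compound 4 (0.53 log units; beyond the scatter) and a 4.8-fold lower number from compound 2 to compound 4 (0.68 log units; beyond the scatter), whereas adding chloro to the 2-hydroxyphenyl ring had stayed within the scatter. For the compounds shown here, measured against the 4-bromophenyl group, the same change gives a 14-fold lower number from compound 1 to compound 4 (1.14 log units; beyond the scatter), the only step in this set rated large. Nothing available explains why this group gives the lowest number.

The compounds shown leave open whether the lower number follows the second hydroxyl or the placement of the hydroxyls, as 3,4-dihydroxyphenyl and 2-hydroxyphenyl differ in both. Also open, as far as these compounds go, is how methoxy groups or an amine in place of those hydroxyls would read in this assay.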